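The source may report more compounds than this note shows. Statements on the series, on what has been measured and on what is new or still open speak of the compounds shown alone.

For the measured compounds named here, in an ADME assay on L6 cells (Rattus norvegicus) for cytotoxicity, read by resazurin assay, with a stated time of 72 h (on this read-out higher numbers stand for weaker inhibition and lower numbers for stronger inhibition), compound 3 `O=C(NC(=O)c1ccccc1O)c1ccc(OC(F)(F)F)cc1` gives 84 ug/mL, the higher of the two exact numbers so far, and compound 1 `CC(C)(C)c1ccc(C(=O)NC(=O)c2ccccc2O)cc1` gives 2.3 ug/mL. Compound 2 `O=C(NC(=O)c1ccccc1O)c1ccc(-c2ccccc2)cc1` reads > 100 ug/mL, which is a limit of the assay and not a number. Compound 4 `COc1ccc(C(=O)NC(=O)c2ccccc2O)cc1` differs from compound 3 by methyl in place of trifluoromethyl on an oxygen on an aromatic ring. Going by the values given here, no measured step makes this exact change. The large steps, a 37-fold higher number from compound 1 to compound 3 (1.56 log units; beyond the scatter) and an at least 43-fold higher number from compound 1 to compound 2 (1.63 log units; beyond the scatter), both start from tert-butyl, whereas an at least 1.1-fold lower number from compound 2 to compound 3 (0.07 log units; that floor lies within the scatter) has a floor within the scatter. Tert-butyl plays no part here, so only a small step toward a lower number is expected in this assay, possibly within the scatter: the estimate is a 1.7-fold lower number from compound 3 to compound 4 (0.23 log units; within the scatter). For compound 4 the expected value is 50 ug/mL, with an estimated range of 12 ug/mL to 100 ug/mL.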

Compound 4, half-maximal inhibitory concentration: 39 ug/mL
Compound 4: the middle estimate sits 1.3-fold (0.11 log units) above what was measured, and the stated range covers the measured number.
By their numbers in this assay, from the lowest: compound 1; then compound 4; then compound 3. At a limit, above all of these: compound 2.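

In this assay, for the compounds shown here, changing only the group on the oxygen gives the first direct reading of this swap, a 2.2-fold lower number from compound 3 to compound 4 (0.33 log units; beyond the scatter), a modest step. Methoxy also stays well apart from tert-butyl, a 17-fold higher number from compound 1 to compound 4 (1.23 log units; beyond the scatter), so the lowest number still belongs to tert-butyl alone. Only a floor can be read against phenyl, an at least 2.5-fold lower number from compound 2 to compound 4 (0.40 log units; beyond the scatter), because that compound stands at a limit of the assay: the limit of > 100 ug/mL in this assay, at which 1 of the 4 values shown sits.

The compounds shown leave open how an amine at this place would read. They also leave open whether a longer chain on the oxygen, such as ethyl, would shift the number further.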